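The compounds below may be only part of what the source reports. "The series", "measured", "known", "first", "only" and "open" are said of these compounds alone.

Measured so far:
compound 1 `O=C([C@H]1CC2CCC1C2)N1CC(c2nc(-c3ccccc3)no2)C1` — 120 nM
compound 2 `O=C([C@H]1CC2CCC1C2)N1CC(c2nc(-c3cccc(F)c3)no2)C1` — 72 nM
compound 3 `CC1CCCC(C(=O)N2CC(c3nc(-c4cccc(Cl)c4)no3)C2)C1` — 410 nM

In an assay on HEK293 cells for positive allosteric modulation of metabotropic glutamate receptor 5 (Homo sapiens), read by FLIPR (a lower number here means that less compound is needed, a higher number that more compound is needed for the effect), compound 2 gives the lowest of the three numbers; against compound 1 this is only a 1.7-fold lower number from compound 1 to compound 2 (0.22 log units; within the scatter), while the number for compound 3 lies well beyond the scatter of compound 2.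

Compound 4 `O=C(c1ccc(F)c(F)c1)N1CC(c2nc(-c3cccc(F)c3)no2)C1` differs from compound 2 by a group of 8 heavy atoms (6 carbon, 2 fluorine; one six-membered aromatic ring of carbon only) in place of a group of 7 heavy atoms (7 carbon; 2 five-membered non-aromatic rings of carbon only), on a carbonyl carbon: a 3,4-difluorophenyl in place of the two fused five-membered non-aromatic rings on the carbonyl carbon.

Within the data shown here, none of the measured steps touches this carbonyl substituent; the only step in hand concerns the aromatic fluoro, and compound 3 differs from compound 2 in two places at once, so its value shows nothing single. The expected change for compound 4 is therefore loosely bounded, a 3.5-fold higher number from compound 2 to compound 4 (0.54 log units; beyond the scatter), leaning toward a higher number. Estimate for compound 4 in this assay: 250 nM, range 60 nM to 1000 nM.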

Compound 4, half-maximal effective concentration: 3200 nM
Estimate against measurement, compound 4: 13-fold (1.11 log units) below; the whole stated range lies below it.
By their numbers in this assay, from the lowest: compounds 2 and 1 (each within the scatter of the next); then compound 3; then compound 4.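

Among these compounds, at the carbonyl carbon, a 3,4-difluorophenyl in place of the two fused five-membered non-aromatic rings gives a 44-fold higher number from compound 2 to compound 4 (1.65 log units; beyond the scatter) in this assay, whereas the only earlier single step, a 1.7-fold lower number from compound 1 to compound 2 (0.22 log units; within the scatter), concerned the aromatic fluoro. This carbonyl substituent is therefore a position where one change can shift the number strongly, even with similar heavy-atom counts in the leaving and entering groups. No measurement at hand gives a cause for this step. Going by these compounds, whether the loss follows the aromatic ring itself or its two fluoro groups remains open. An unsubstituted phenyl or a piperidine on this carbonyl carbon could separate these readings.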